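Rat Clearance Expected for a Methylated Analogue of Compound 2

The source may hold more compounds than are shown below. What is called first, only, known or untested is meant among the compounds shown, and "the series" means these compounds.

Measured so far:
compound 1 `C=CC(=O)N1CC[C@H](N2C(=O)N(c3ccccc3)Cc3cnc(Nc4cccc(N5CCN(C)CC5)c4)nc32)C1`: 565 mL/min/kg
compound 2 `C=CC(=O)N1CC[C@H](N2C(=O)N(c3ccccc3)Cc3cnc(Nc4ccc(N5CCN(C)CC5)cc4)nc32)C1`: 203 mL/min/kg
compound 3 `C=CC(=O)N1CC[C@H](N2C(=O)N(c3ccccc3)Cc3cnc(Nc4ccc(N5CCN(C)CC5)cc4OC)nc32)C1`: 200 mL/min/kg

In an ADME assay on the whole organism (strain Sprague-Dawley) for pharmacokinetics, with Rattus norvegicus as the target, read by LC-MS, at a dose of 25 mg/kg by the oral route (on this read-out lower numbers stand for slow clearance and higher numbers for fast clearance), compound 2 gives 203 mL/min/kg, the second highest of the three numbers. Compound 3 sits closest, and the step of a 1.0-fold lower number from compound 2 to compound 3 (0.01 log units; within the scatter) lies within the scatter. Compound 1 gives 565 mL/min/kg, a higher number that lies beyond the scatter of compound 2.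

Compound 4 `C=CC(=O)N1CC[C@H](N2C(=O)N(c3ccccc3)Cc3cnc(Nc4ccc(N5CCN(C)CC5)c(C)c4)nc32)C1` differs from compound 2 by methyl in place of hydrogen on an aromatic carbon, ortho to the 4-methylpiperazin-1-yl group. Among the measured compounds shown here, the only step that bears on a small substituent entering this ring is a 1.0-fold lower number from compound 2 to compound 3 (0.01 log units; within the scatter), which stayed within the scatter. On that basis no step beyond the scatter is expected, and the change from compound 2 to compound 4 is estimated as a 1.0-fold higher number from compound 2 to compound 4 (0.01 log units; within the scatter). Compound 4 is therefore expected to give 210 mL/min/kg, within 100 mL/min/kg to 440 mL/min/kg.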

Compound 4, clearance: 167 mL/min/kg
Compound 4: middle estimate off by 1.3-fold (0.10 log units), on the high side; measured number inside the range.
By their numbers in this assay, from the lowest: compounds 4, 3 and 2 (each within the scatter of the next); then compound 1.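

In this assay methyl in place of hydrogen, ortho to the 4-methylpiperazin-1-yl group, gives a 1.2-fold lower number from compound 2 to compound 4 (0.08 log units; within the scatter) and so adds a carbon at this position without a step beyond the scatter. The earlier 1.0-fold lower number from compound 2 to compound 3 (0.01 log units; within the scatter) concerned methoxy and did not test this position. Nothing at hand explains the result.

From the compounds shown here alone, whether a fluorine, a primary amine or a carboxylic acid at this position would also stay within the scatter remains open. So does the effect of a longer chain here.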